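The source may hold more compounds than are shown below. What is called first, only, known or untested is meant among the compounds shown, and "the series" means these compounds.

Going by the values given here, compound 3 `COc1ccc(-n2c(SC(C)C(=O)Nc3nc(C)c(Cl)cc3Cl)nc3ccccc32)cc1` is the only member of this small set with a definite number in an ADME assay on Vero cells (Chlorocebus sabaeus) for cytotoxicity, read by MTT assay, with a stated time of 24 h; a higher number here means that more compound is tolerated, a lower number that less compound is tolerated: compound 3 gives 7250 nM. Compound 1 `Cc1ccc(NC(=O)C(C)Sc2nc3ccccc3n2Cc2ccccc2)c(Cl)c1` reaches only a limit of the assay in this assay, > 75000 nM, which is the limit of > 75000 nM in this assay, at which 1 of the 3 values shown sits. For compound 2 `COc1ccc(-n2c(SC(C)C(=O)Nc3nc(C)cc(Cl)n3)nc3ccccc32)cc1` this assay records "not determined" (no result reported). Compound 4 `COc1ccc(-n2c(SC(C)C(=O)Nc3ccc(C)cc3Cl)nc3ccccc32)cc1` has not yet been measured; compared with compound 3 it carries 2-chloro-4-methylphenyl in place of 3,5-dichloro-6-methylpyridin-2-yl on an amide-type nitrogen. Among the compounds with values here, with no measured step to lean on, the size of the change is open, yet compound 4 is expected to sit somewhat above compound 3, roughly a 2.8-fold higher number from compound 3 to compound 4 (0.44 log units; beyond the scatter), with a real chance that only a limit is reported. The estimate for compound 4 in this assay is 20000 nM, between 5000 nM and 75000 nM.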

Compound 4, half-maximal cytotoxic concentration: > 75000 nM
Compound 4: only a limit was reported; the forecaster's own chance of this, stated with the estimate: 40%; middle value at least 3.7-fold (0.57 log units) from the limit.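

On the amide-type nitrogen, 2-chloro-4-methylphenyl in place of 3,5-dichloro-6-methylpyridin-2-yl gives an at least 10-fold higher number from compound 3 to compound 4 (1.01 log units; beyond the scatter) in this assay and so shows that a change at this position alone can produce a large step. The value of compound 4 is a limit of the assay. The step between compound 1 and compound 4 cannot be read, so the exchange of benzyl for 4-methoxyphenyl on the aromatic nitrogen gains no size here.

Which part of the change from compound 3 to compound 4 carries the step stays open: the ring nitrogen and one chlorine leave together. Also open is whether a carboxylic acid or an amine on the 2-chloro-4-methylphenyl group would remain at the limit: the limit of > 75000 nM in this assay, at which 2 of the 4 values shown sit.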